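The source may report more compounds than this note shows. Statements on the series, on what has been measured and on what is new or still open speak of the compounds shown alone.

Compound 1 `Nc1nc(N)c2c(-c3cc4ccccc4o3)cn([C@@H]3O[C@H](CO)[C@@H](O)[C@H]3O)c2n1`, in a functional assay on CCRF-CEM cells (Homo sapiens), read by MTT assay, with a stated time of 72 h; a lower number here means a stronger inhibitor, a higher number a weaker inhibitor: > 20000 nM, a limit of the assay rather than a number.
Compound 2 `Cc1nc(N)c2c(-c3cc4ccccc4o3)cn([C@@H]3O[C@H](CO)[C@@H](O)[C@H]3O)c2n1`, in this assay: > 20000 nM, again a limit.
Compound 3 `CN(C)c1ncnc2c1c(-c1ccoc1)cn2[C@@H]1O[C@H](CO)[C@@H](O)[C@H]1O`, in this assay: 13300 nM.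

Compound 2 therefore stands at the limit of > 20000 nM in this assay, at which 2 of the 3 values shown sit, so its value is a limit and not a number. Within the data shown here, the one measured step, a step that the two limits leave unreadable from compound 1 to compound 2, cannot be read in size, and so no measured step gives a guide to what follows. Compound 4 `Cc1nc(N)c2c(-c3ccco3)cn([C@@H]3O[C@H](CO)[C@@H](O)[C@H]3O)c2n1` differs from compound 2 by furan-2-yl in place of 1-benzofuran-2-yl on an aromatic carbon. Among the measured compounds shown here, no measured pair shows this change. For compound 4 a step that the limit leaves unreadable from compound 2 to compound 4 is expected, with a fair chance that the result is again only a limit. Compound 4 is estimated at 25000 nM, within a range from 8000 nM to 80000 nM.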

Compound 4, half-maximal inhibitory concentration: > 100000 nM
Compound 4 ended at the assay's limit (the forecaster's own chance of this, stated with the estimate: 65%); at least 4.0-fold (0.60 log units) between middle value and limit.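

Compound 2 and compound 4 both ended at limits of this assay, not at numbers, so the step between them cannot be read. The compounds shown leave open whether furan-2-yl in place of 1-benzofuran-2-yl changes the inhibition at all.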